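A few compounds are considered here, and "the series" means these few. Any claim that something is new, unique, unknown or untested is made for them only; others in the source may bear on it.

Measured in a functional assay on MGC-803 cells (Homo sapiens) for antiproliferative activity, read by MTT assay, with a stated time of 72 h; on this read-out higher numbers stand for weaker inhibition and lower numbers for stronger inhibition:
- compound 1 `CCCSc1nc(N/N=C(\C)c2ccccc2O)c2nnn(Cc3ccc(Cl)cc3)c2n1`: 7100 nM
- compound 2 `CCCSc1nc(N/N=C(\C)c2ccc(O)cc2)c2nnn(Cc3ccccc3)c2n1`: 16700 nM
- compound 3 `C/C(=N\Nc1nc(SCc2ccccc2)nc2c1nnn2Cc1ccccc1)c1ccccc1O`: 850 nM

Compound 2 has the highest of the three numbers and is the weakest inhibitor in this assay. Compound 1 is its nearest neighbour and compound 3 the furthest, both lower by more than the scatter. Among the compounds with values here, no two measured compounds differ in one place only, so the effect of a single change cannot be read directly from these data.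

Compound 4 `CCCSc1nc(N/N=C(\C)c2ccccc2)c2nnn(Cc3ccccc3)c2n1` carries hydrogen in place of hydroxy on an aromatic carbon, para to a large group, turning the 4-hydroxyphenyl of compound 2 into phenyl: hydrogen in place of hydroxy on an aromatic carbon. Within the data shown here, with no measured precedent for this change, the starting point is compound 2 at 16700 nM. A step within the scatter is expected in this assay, with a slight lean towards a lower number.

The estimate corresponds to an expected step of a 1.3-fold lower number from compound 2 to compound 4 (0.11 log units; within the scatter). For compound 4 the expected value is 13000 nM, with an estimated range of 5000 nM to 30000 nM.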

Compound 4, half-maximal inhibitory concentration: 25400 nM
For compound 4 the middle estimate is 2.0-fold (0.29 log units) below the measured one; the range from low to high includes it.
By their numbers in this assay, from the lowest: compound 3; then compound 1; then compounds 2 and 4 (each within the scatter of the next).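

In this assay, within the data shown here, the step from hydroxy to hydrogen on this aromatic carbon, para to a large group, is a 1.5-fold higher number from compound 2 to compound 4 (0.18 log units; within the scatter) and gives the first direct reading of a single change. At this position, the 4-hydroxyphenyl of compound 2 and the phenyl of compound 4 cannot be told apart on this read-out, so this pair shows no measurable dependence on the hydroxy, with its one hydrogen-bond donor and one hydrogen-bond acceptor. No measurement at hand accounts for this result.

From the compounds shown here alone, it remains open whether an amine, a methoxy group or a carboxylic acid at this position would also stay within the scatter of compound 2. Also open, going by these compounds, is whether the same change would give a similar step on the scaffolds of compound 1 and compound 3.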